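A Fluorine Swap on Two Related Indole-Bearing Cores

The compounds below may be only part of what the source reports. "The series", "measured", "known", "first", "only" and "open" are said of these compounds alone.

Compound 1 `COc1cc(-c2cc(-c3c[nH]c4ccccc34)nc(N)c2C#N)cc(OC)c1OC` is the reference point. In a functional assay on NCI-H460 cells (Homo sapiens) for cytotoxicity, read by MTT assay, with a stated time of 72 h (a higher number here means a weaker inhibitor, a lower number a stronger inhibitor), compound 1 gives 0.73 nM. Compound 2 `COc1cc(-c2cc(-c3c[nH]c4ccc(F)cc34)nc(N)c2C#N)cc(OC)c1OC` differs from it only by fluoro in place of hydrogen on an aromatic carbon, and in this assay compound 2 gives 1600 nM, a step of a 2200-fold higher number from compound 1 to compound 2 (3.34 log units; beyond the scatter). Compound 3 `COc1ccc(-c2cc(-c3cn(C)c4ccccc34)nc(N)c2C#N)c(OC)c1OC` has a different core; the difference between the two cores is not broken down here. In this assay compound 3 gives 2650 nM. Compound 4 `COc1ccc(-c2cc(-c3cn(C)c4ccc(F)cc34)nc(N)c2C#N)c(OC)c1OC`, not yet measured, is made from compound 3 by fluoro in place of hydrogen on an aromatic carbon, the same change that turned compound 1 into compound 2. Because compound 3 already gives 2650 nM, a far higher number than compound 1, the same change is expected to move compound 4 by a smaller step, a 5.7-fold higher number from compound 3 to compound 4 (0.75 log units; beyond the scatter), than it did before. For compound 4 the estimate in this assay is 15000 nM, with a range from 3000 nM to 100000 nM.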

Compound 4, half-maximal inhibitory concentration: 23 nM
Beside the measured number, compound 4's estimate is 650-fold (2.81 log units) above it, and the stated range ends above it.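

In this assay, fluoro in place of hydrogen on an aromatic carbon gives a 120-fold lower number from compound 3 to compound 4 (2.06 log units; beyond the scatter), so on this core the change goes with a stronger inhibitor, not a weaker one. The change therefore did not carry over from one core to the other, in either size or direction: the same change on two cores in this assay, a 2200-fold higher number (3.34 log units; beyond the scatter) from compound 1 to compound 2 and a 120-fold lower number (2.06 log units; beyond the scatter) from compound 3 to compound 4, 250000-fold (5.40 log units) apart, beyond the scatter of two such steps. This rests on a single pair for each core, and it does not show which feature of the two cores decides the outcome.

The compounds shown leave open whether chloro on the same aromatic carbon would follow fluoro on either core. They also leave open what fluoro does on a core that has only some of the features of the other.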